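Series notes: compound 4 expected from compounds 1 to 3

This account rests on a few compounds, and the source may have more. Where it says the series, first, only, none or still open, it means among the compounds named here.

Measured so far:
compound 1 `CCOC(=O)C12C(=O)OCC=C1COC2c1ccccc1`: > 1000000 nM
compound 2 `CCOC(=O)C12C(=O)OCC=C1COC2c1ccc(OC)cc1`: > 1000000 nM
compound 3 `CCOC(=O)C12C(=O)OCC=C1COC2c1ccc([N+](=O)[O-])cc1`: > 1000000 nM

In a functional assay on QGY cells (Homo sapiens) for cytotoxicity, read by MTT assay (a higher number here means a weaker inhibitor, a lower number a stronger inhibitor), compound 1 gives > 1000000 nM, which is a limit of the assay and not a number. Compound 2 likewise gives only a limit in this assay. Compound 3 also gives only a limit in this assay. Compound 1 therefore stands at the limit, and the two further values shown sit at the same limit (the limit of > 1000000 nM in this assay, at which 3 of the 3 values shown sit). The steps a step that the two limits leave unreadable from compound 1 to compound 2, a step that the two limits leave unreadable from compound 1 to compound 3 and a step that the two limits leave unreadable from compound 2 to compound 3 cannot be sized because the limit of > 1000000 nM in this assay, at which 3 of the 3 values shown sit, holds every value at the same limit.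

Compound 4 `CCOC(=O)C12C(=O)OCC=C1COC2c1ccco1` differs from compound 1 by furan-2-yl in place of phenyl on a saturated ring carbon. For the measured compounds named here, none of the measured steps touches this kind of change: they alter a substituent on the aromatic ring while keeping the phenyl, and none is readable. There is no basis in the measured compounds for a shift away from the limit. Compound 4 is therefore expected to give 1000000 nM in this assay, with a range from 300000 nM to 3000000 nM. The expected step of a number no higher from compound 1 to compound 4 (the limit leaves the size open) is none beyond the scatter, and most likely only a limit will be reported.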

Compound 4, half-maximal inhibitory concentration: > 1000000 nM
Compound 4 gave a limit, no number; the forecaster's own chance of this, stated with the estimate: 85%; the middle value lies on the limit itself.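

No step can be read from compound 1 to compound 4 in this assay, because each value is a limit of the assay and not a number: the limit of > 1000000 nM in this assay, at which 4 of the 4 values shown sit.

The compounds shown leave open whether furan-2-yl in place of phenyl, or any substituent on the phenyl, changes potency on the shared core.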